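This account rests on a few compounds, and the source may have more. Where it says the series, first, only, none or still open, it means among the compounds named here.

Measured compounds:
Compound 1, `O=C(COc1ccc(C(=O)/C=C/c2ccccc2Br)cc1)N[C@H]1CCOC1=O`: 3540 nM
Compound 2, `C=CCc1ccc(OCCSC(=S)N[C@H]2CCOC2=O)c(OC)c1`: > 64000 nM

For the measured compounds named here, in a functional assay on DU-145 cells (Homo sapiens) for antiproliferative activity, read by MTT assay, with a stated time of 72 h (a lower number here means a stronger inhibitor, a higher number a weaker inhibitor), compound 1 gives 3540 nM, and this is the only value in the set that is a number rather than a limit. For compound 2 the assay reports only a limit, > 64000 nM, so no number can be set against it; this is the point at which (the limit of > 64000 nM in this assay, at which 1 of the 2 values shown sits), and one of the two values shown sits there. Going by the values given here, no step between two measured compounds is available, since compound 1 and compound 2 are not related by a change in one place, and their two values show only that compound 1 has a measured number while compound 2 does not.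

Compound 3, `O=C(COc1ccc(C(=O)/C=C/c2cccc([N+](=O)[O-])c2)cc1)N[C@H]1CCOC1=O`, has not yet been measured. It differs from compound 1 in one place: 3-nitrophenyl in place of 2-bromophenyl on a double-bonded chain carbon bound to a double-bonded chain carbon. Since no measured step of this kind is shown, the expected size of the change rests on compound 1 alone. The step of a 1.1-fold higher number from compound 1 to compound 3 (0.05 log units; within the scatter) is expected to stay within the usual scatter. Compound 3 is therefore estimated at 4000 nM, with a range from 1500 nM to 12000 nM.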

Compound 3, half-maximal inhibitory concentration: 41800 nM
For compound 3 the middle estimate is 10-fold (1.02 log units) below the measured one; the whole stated range lies below it.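

At this place, on a double-bonded chain carbon bound to a double-bonded chain carbon, the aromatic group is not freely exchangeable: in this assay, 3-nitrophenyl in place of 2-bromophenyl gives a 12-fold higher number from compound 1 to compound 3 (1.07 log units; beyond the scatter), a large step that makes compound 3 the weaker inhibitor. For the compounds shown here, this is the first step in the set that can be read, and it shows that the activity of the core of compound 1 responds strongly to the group at this one place, which the two earlier compounds, not related by a change in one place, could not show. Both ends of the step are true numbers, and the only reading in the set that is a limit rather than a number belongs to compound 2: the limit of > 64000 nM in this assay, at which 1 of the 3 values shown sits.

Going by these compounds alone, the single step replaces one whole group with another, so it cannot tell whether the loss of the bromine, the arrival of the nitro group or the different place of the substituent on the ring carries the change. From the compounds shown here alone, how an unsubstituted phenyl, an aminophenyl or a methoxyphenyl would behave at this place remains open.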